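From pent-1-en-1-yl to 2-chloroethyl on the carbonyl

This account rests on a few compounds, and the source may have more. Where it says the series, first, only, none or still open, it means among the compounds named here.

Among the measured compounds shown here, in a functional assay on KYSE-450 cells (Homo sapiens) for inhibition, read by MTT assay, with a stated time of 48 h (a lower number here means a stronger inhibitor, a higher number a weaker inhibitor), compound 2 `CCC/C=C/C(=O)N(Cc1ccc(OC)c(O)c1)c1cc(OC)c(OC)c(OC)c1` gives 57 nM and holds the lower of the two numbers so far, while compound 1 `COCC(=O)N(Cc1ccc(OC)c(O)c1)c1cc(OC)c(OC)c(OC)c1` gives 460 nM on the same read-out. Compound 3 `COc1ccc(CN(C(=O)CCCl)c2cc(OC)c(OC)c(OC)c2)cc1O` carries 2-chloroethyl in place of pent-1-en-1-yl on a carbonyl carbon, a change counted as 2-chloroethyl in place of pent-1-en-1-yl on a carbonyl carbon in full.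

For the measured compounds named here, one measured step bears on this place. The modest 8.1-fold lower number from compound 1 to compound 2 (0.91 log units; beyond the scatter) came with pent-1-en-1-yl replacing methoxymethyl on a carbonyl carbon, and it lies beyond the scatter. Going by the values given here, compound 3 gives that group up again, so part of this gain is expected to be lost, although no measured compound holds 2-chloroethyl. A rise in this assay is therefore expected, estimated as a 3.5-fold higher number from compound 2 to compound 3 (0.55 log units; beyond the scatter) and smaller than the earlier step. For compound 3 the estimated value is 200 nM with an expected range from 70 nM to 600 nM in this read-out.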

Compound 3, half-maximal inhibitory concentration: 110 nM
For compound 3 the middle estimate is 1.8-fold (0.26 log units) above the measured one; the measured number falls inside the stated range.
By their numbers in this assay, from the lowest: compounds 2 and 3 (each within the scatter of the next); then compound 1.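

In this assay, the double bond and the longer chain of pent-1-en-1-yl prove dispensable at this carbonyl carbon, since the change to 2-chloroethyl gives a 1.9-fold higher number from compound 2 to compound 3 (0.29 log units; within the scatter). The gain over the methoxymethyl amide therefore does not belong to pent-1-en-1-yl alone: the same position also gives a 4.2-fold lower number from compound 1 to compound 3 (0.62 log units; beyond the scatter), so two different carbon chains, one saturated and one not, both stand apart from compound 1. Nothing available explains why either chain differs from methoxymethyl.

The compounds shown leave open whether the chlorine contributes at all, a question that a plain ethyl group at this carbonyl carbon would address. They also leave open how far the chain can be extended or changed, for instance with a saturated pentyl chain or a terminal amine.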